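Notes on the benzyl substituent of the shared core

This account rests on a few compounds, and the source may have more. Where it says the series, first, only, none or still open, it means among the compounds named here.

Measured so far:
Compound 1 `COc1ccc(-c2ccc3c(c2)C(=O)C(=O)N3Cc2cccc(Cl)c2)cc1`: in a functional assay on HepG2 cells (Homo sapiens) for antiproliferative activity, read by MTT assay, with a stated time of 48 h (on this read-out higher numbers stand for weaker inhibition and lower numbers for stronger inhibition), compound 1 gives 320 nM.
Compound 2 `COc1ccc(CN2C(=O)C(=O)c3cc(-c4ccc(OC)cc4)ccc32)cc1`: in this assay compound 2 gives 50 nM.

Among the measured compounds shown here, compound 2 stands at the lower of the two numbers; the only neighbour is compound 1, and the step of a 6.4-fold lower number from compound 1 to compound 2 (0.81 log units; beyond the scatter) is the single measured change at the saturated chain carbon bound to the amide-type nitrogen in the ring.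

Compound 3 `COc1ccc(-c2ccc3c(c2)C(=O)C(=O)N3Cc2ccc3ccccc3c2)cc1` carries the change (naphthalen-2-yl in place of 4-methoxyphenyl on a saturated chain carbon bound to an amide-type nitrogen in a ring). No measured step covers this exchange; the one step at this place, a 6.4-fold lower number from compound 1 to compound 2 (0.81 log units; beyond the scatter), shows that the group here can move the number well beyond the scatter, but the direction for naphthalen-2-yl is not shown. The expectation for compound 3 is therefore a modest step, a 2.4-fold higher number from compound 2 to compound 3 (0.38 log units; beyond the scatter), with a wide range.

Estimated for compound 3 in this assay: 120 nM, range 35 nM to 450 nM.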

Compound 3, half-maximal inhibitory concentration: 380 nM
Estimate against measurement, compound 3: 3.2-fold (0.50 log units) below, within the range that was stated.
By their numbers in this assay, from the lowest: compound 2; then compounds 1 and 3 (each within the scatter of the next).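

In this assay, naphthalen-2-yl in place of 4-methoxyphenyl gives a 7.6-fold higher number from compound 2 to compound 3 (0.88 log units; beyond the scatter) and so supplies the direction for this exchange on the saturated chain carbon bound to an amide-type nitrogen in a ring, which the earlier step could not show. Naphthalen-2-yl in place of 3-chlorophenyl gives a 1.2-fold higher number from compound 1 to compound 3 (0.07 log units; within the scatter) and leaves these two groups unresolved, so that among the three compounds only the 4-methoxyphenyl of compound 2 stands apart, with steps beyond the scatter to both others. No available evidence bears on this result.

The compounds shown leave open whether the lower number of compound 2 depends on the methoxy group itself or on its place on the ring. A comparison of 3-methoxyphenyl and 4-chlorophenyl with plain phenyl on the same carbon would separate these two readings.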